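Working notes on an aryl ketone replacement in the series

The source may hold more compounds than are shown below. What is called first, only, known or untested is meant among the compounds shown, and "the series" means these compounds.

Compound 1 `C#CCOc1ccc(/C=C/C(=O)c2cccc(OC)c2)cc1OC` gives 1010 nM in a functional assay on HCT-116 cells (Homo sapiens) for cytotoxicity, with a stated time of 72 h (on this read-out lower numbers stand for stronger inhibition and higher numbers for weaker inhibition), the second highest of the three numbers in hand. Compound 3 `C#CCOc1ccc(/C=C/C(=O)c2ccc(OC)c(OC)c2)cc1OC` gives 320 nM, while compound 2 `C=CCOc1ccc(C=O)cc1OC`, a much smaller aldehyde without the aryl ketone, gives 8020 nM. Among the measured compounds shown here, the only single-place step available is a 3.2-fold lower number from compound 1 to compound 3 (0.50 log units; beyond the scatter), where a further methoxy on the aryl ketone ring lowered the number. Compound 4 `C#CCOc1ccc(/C=C/C(=O)c2ccccc2C)cc1OC` differs from compound 1 by 2-methylphenyl in place of 3-methoxyphenyl on a carbonyl carbon. For the measured compounds named here, no measured step removes a methoxy from this ring or installs a methyl, so the direction rests on the opposite sense of the step to compound 3. A modest rise is expected, a 2.2-fold higher number from compound 1 to compound 4 (0.34 log units; beyond the scatter), giving an estimated 2200 nM for compound 4, within 800 nM to 6000 nM.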

Compound 4, half-maximal inhibitory concentration: 1060 nM
Compound 4: the middle estimate sits 2.1-fold (0.32 log units) above what was measured; the range from low to high includes it.
By their numbers in this assay, from the lowest: compound 3; then compounds 1 and 4 (each within the scatter of the next); then compound 2.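

At the carbonyl carbon, 2-methylphenyl in place of 3-methoxyphenyl leaves the number in this assay within the scatter (a 1.0-fold higher number from compound 1 to compound 4 (0.02 log units; within the scatter)). The earlier step (a 3.2-fold lower number from compound 1 to compound 3 (0.50 log units; beyond the scatter)) showed only that a further methoxy lowers the number; this ring evidently needs no methoxy to hold the level of compound 1. No available evidence bears on this result.

Whether 2-methylphenyl and 3-methoxyphenyl match for the same reason stays open. So does how an amine or a carboxylic acid on this ring would read out.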